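From 3-(trifluoromethyl)phenyl to 3,5-difluorophenyl on the shared core

The compounds below may be only part of what the source reports. "The series", "measured", "known", "first", "only" and "open" are said of these compounds alone.

Values measured in a toxicity assay on HaCaT cells (Homo sapiens) for cytotoxicity, read by MTT assay; on this read-out lower numbers stand for stronger inhibition and higher numbers for weaker inhibition:
- Compound 1 `CCc1ccc(-n2nc(-c3ccc(C(F)(F)F)cc3O)nc2-c2ccccc2O)cc1`: 57000 nM
- Compound 2 `Oc1cc(C(F)(F)F)ccc1-c1nc(-c2ccccc2O)n(-c2ccc(Br)cc2)n1`: 29600 nM
- Compound 3 `Oc1cc(C(F)(F)F)ccc1-c1nc(-c2ccccc2O)n(-c2cccc(C(F)(F)F)c2)n1`: 54300 nM

These three compounds share one core and differ only in the group on an aromatic nitrogen. Compound 3, at 54300 nM, lies within the scatter of both other compounds, so the numbers do not rank it. Compound 4 `Oc1cc(C(F)(F)F)ccc1-c1nc(-c2ccccc2O)n(-c2cc(F)cc(F)c2)n1` has 3,5-difluorophenyl in place of 3-(trifluoromethyl)phenyl on that nitrogen: 3,5-difluorophenyl in place of 3-(trifluoromethyl)phenyl on an aromatic nitrogen.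

For the measured compounds named here, three measured steps bear on this change, since each swaps the group at that same place: a 1.9-fold lower number from compound 1 to compound 2 (0.28 log units; within the scatter), a 1.0-fold lower number from compound 1 to compound 3 (0.02 log units; within the scatter) and a 1.8-fold higher number from compound 2 to compound 3 (0.26 log units; within the scatter). All of them stay within the scatter, so a swap here has not yet shifted this assay measurably. Going by the values given here, no measured compound carries 3,5-difluorophenyl, which leaves this expectation resting on just three neighbours. The expected change is a 1.2-fold lower number from compound 3 to compound 4 (0.08 log units; within the scatter), which would be no real shift beyond the scatter. The estimate for compound 4 is 45000 nM, with an expected range from 24000 nM to 85000 nM.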

Compound 4, half-maximal inhibitory concentration: 45400 nM
The estimate for compound 4 lay 1.0-fold (0.00 log units) below the measured number, and the stated range covers the measured number.
By their numbers in this assay, from the lowest: compounds 2, 4, 3 and 1 (each within the scatter of the next).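

In this assay, 3,5-difluorophenyl on the aromatic nitrogen gives a 1.2-fold lower number from compound 3 to compound 4 (0.08 log units; within the scatter) and also a 1.5-fold higher number from compound 2 to compound 4 (0.19 log units; within the scatter) and a 1.3-fold lower number from compound 1 to compound 4 (0.10 log units; within the scatter). A fourth substituted phenyl group at this place therefore separates from none of the other three, and all four compounds now lie within the scatter of one another, so this change has brought no measurable shift. No measurement is available to explain why these values stay so close.

Every group shown here is a substituted phenyl ring, so it remains open whether an amine, a carboxylic acid or a longer chain on that phenyl ring would move the number beyond the scatter. The compounds also leave open whether replacing the phenyl ring itself with a plain alkyl chain would do so.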